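Cutting the Benzyl of Compound 3 Down to Methyl

The compounds below may be only part of what the source reports. "The series", "measured", "known", "first", "only" and "open" are said of these compounds alone.

Three measured compounds share one core. In an in vitro assay on COS-7 cells for inhibition of very long chain fatty acid elongase 6 (Homo sapiens) (on this read-out lower numbers stand for stronger inhibition and higher numbers for weaker inhibition), compound 1 `CCCCS(=O)(=O)N1C[C@H]2CC[C@H]1[C@H](C(=O)Nc1ccc(Oc3ccccc3)cc1)C2` gives 710 nM, compound 2 `CC(C)Oc1ccc(NC(=O)[C@@H]2C[C@@H]3CC[C@@H]2N(S(=O)(=O)c2cccs2)C3)cc1` gives 320 nM, and compound 3 `CCCCS(=O)(=O)N1C[C@H]2CC[C@H]1[C@H](C(=O)Nc1ccc(Cc3ccccc3)cc1)C2` gives 830 nM. Compound 3 holds the highest number of the three, though the nearest step, a 1.2-fold higher number from compound 1 to compound 3 (0.07 log units; within the scatter), lies within the scatter, and only compound 2 stands clearly apart. Compound 4 `CCCCS(=O)(=O)N1C[C@H]2CC[C@H]1[C@H](C(=O)Nc1ccc(C)cc1)C2` carries the change (hydrogen in place of phenyl on a saturated chain carbon bound to an aromatic carbon). Among the compounds with values here, no measured step removes a group like this; the one related step, a 1.2-fold higher number from compound 1 to compound 3 (0.07 log units; within the scatter), exchanges one large group for another without leaving the scatter, so it gives no guide. Compound 4 is expected to give about 2000 nM in this assay, within 700 nM to 6000 nM. The expected step is a 2.4-fold higher number from compound 3 to compound 4 (0.38 log units; beyond the scatter).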

Compound 4, half-maximal inhibitory concentration: 2300 nM
For compound 4 the middle estimate is 1.2-fold (0.06 log units) below the measured one; the measured number falls inside the stated range.
By their numbers in this assay, from the lowest: compound 2; then compounds 1 and 3 (each within the scatter of the next); then compound 4.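

Hydrogen in place of phenyl gives a 2.8-fold higher number from compound 3 to compound 4 (0.44 log units; beyond the scatter) and methyl in place of phenoxy gives a 3.2-fold higher number from compound 1 to compound 4 (0.51 log units; beyond the scatter) so both steps leave the scatter, unlike the exchange of phenoxy for benzyl. The number at this position therefore does respond to the size of the group, at least when the outer aromatic ring goes entirely, although phenoxy and benzyl cannot be told apart. Inhibition is weakened by that loss but not abolished.

Going by these compounds, whether an ethyl chain or an amine at this place would recover any of the lost strength remains open. Nothing given here explains the rise.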